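The source may report more compounds than this note shows. Statements on the series, on what has been measured and on what is new or still open speak of the compounds shown alone.

In a functional assay on SW-620 cells (Homo sapiens) for cytotoxicity, read by MTT assay, with a stated time of 72 h (a higher number here means a weaker inhibitor, a lower number a stronger inhibitor), compound 3 `COc1cccc(/C=C2\CCC/C(=C\c3cccc(O)c3)C2=O)c1OC` gives 6400 nM and compound 1 `COc1cccc(/C=C2\CCC/C(=C\c3cccc(Br)c3)C2=O)c1OC` gives 8800 nM, two values within the scatter of each other. Compound 2 `COc1ccccc1/C=C1\CCC/C(=C\c2cccc(OC)c2OC)C1=O` reports only a limit, > 20000 nM.

Compound 4 `COc1cccc(/C=C2\CCC/C(=C\c3ccc(Cl)cc3Cl)C2=O)c1OC` differs from compound 3 by 2,4-dichlorophenyl in place of 3-hydroxyphenyl on a double-bonded chain carbon bound to a double-bonded ring carbon, with 2,4-dichlorophenyl in place of 3-hydroxyphenyl on a double-bonded chain carbon bound to a double-bonded ring carbon.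

Among the measured compounds shown here, three measured steps bear on this change. Hydroxy for bromo gave a 1.4-fold lower number from compound 1 to compound 3 (0.14 log units; within the scatter), within the scatter. The 2-methoxyphenyl group gave an at least 2.2-fold higher number from compound 1 to compound 2 (0.35 log units; beyond the scatter), and 3-hydroxyphenyl in its place gave an at least 3.1-fold lower number from compound 2 to compound 3 (0.49 log units; beyond the scatter), both beyond the scatter. The halogen-bearing compound 1 therefore suggests little movement, while compound 2 leaves some risk of a weaker result.

The expected change is a 1.4-fold higher number from compound 3 to compound 4 (0.15 log units; within the scatter), with no clear step beyond the scatter anticipated. The estimate for compound 4 is 9000 nM, with an expected range of 3500 nM to 20000 nM.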

Compound 4, half-maximal inhibitory concentration: 16300 nM
Estimate against measurement, compound 4: 1.8-fold (0.26 log units) below; low and high end bracket the measured number.
By their numbers in this assay, from the lowest: compounds 3, 1 and 4 (each within the scatter of the next, the first and the last beyond it). At a limit, above all of these: compound 2.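

In this assay, 2,4-dichlorophenyl on this double-bonded chain carbon gives a step beyond the scatter against the hydroxy-bearing ring (a 2.5-fold higher number from compound 3 to compound 4 (0.41 log units; beyond the scatter)), which the bromo-to-hydroxy comparison did not show. Against the other halogen-bearing ring, 2,4-dichlorophenyl in place of 3-bromophenyl gives a 1.9-fold higher number from compound 1 to compound 4 (0.27 log units; within the scatter) and leaves the two halogen-bearing compounds unseparated. 2,4-Dichlorophenyl in place of 2-methoxyphenyl gives an at least 1.2-fold lower number from compound 2 to compound 4 (0.08 log units; that floor lies within the scatter) and no more can be read from this step. Compound 2 is held at a limit: the limit of > 20000 nM in this assay, at which 1 of the 4 values shown sits.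

From the compounds shown here alone, whether a single chloro on this ring differs from 2,4-dichlorophenyl remains open. So does whether an amine or a carboxylic acid in place of the hydroxy would match compound 3.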